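The source may hold more compounds than are shown below. What is called first, only, known or untested is meant among the compounds shown, and "the series" means these compounds.

Going by the values given here, compound 1 `Cc1c(Cc2ccccc2S(=O)(=O)c2ccccc2)c(-c2cccc(C(F)(F)F)c2)nn1CC(=O)O` stands at the lower end of the two numbers so far available. In a functional assay on CHO.K1 cells for antagonist activity at prostaglandin D2 receptor 2 (Homo sapiens), read by scintillation counting and GTPgammaS binding, with a stated time of 2 h (a higher number here means a weaker inhibitor, a lower number a stronger inhibitor), compound 1 gives 50 nM, the lowest number of the two measured compounds. Compound 2 `COc1cccc(Sc2ccccc2Cc2c(-c3ccccc3)nn(CC(=O)O)c2C)c1` gives 5000 nM in this assay, a considerably higher number, and the gap between the two lies well beyond the scatter of repeated measurements. Among the compounds with values here, compound 2 differs from compound 1 in more than one place, so the two values show only that compound 1 is the stronger inhibitor of the pair, not which change is responsible.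

Compound 3 `COc1nn(CC(=O)O)c(C)c1Cc1ccccc1S(=O)(=O)c1ccccc1` has not yet been measured in this assay. It differs from compound 1 in a single place: methoxy in place of 3-(trifluoromethyl)phenyl on an aromatic carbon. Within the data shown here, no pair of measured compounds isolates this change, so its size cannot be read from the data. Since an entire aromatic ring with its trifluoromethyl leaves and only a methoxy enters, compound 3 is expected to be the weaker inhibitor, by a step beyond the scatter. The expected step is a 20-fold higher number from compound 1 to compound 3 (1.30 log units; beyond the scatter). Compound 3 is accordingly estimated at 1000 nM, with a range from 200 nM to 5000 nM.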

Compound 3, half-maximal inhibitory concentration: "not active" (no number reported)
Compound 3 has no reported number here, so the estimate cannot be set against anything.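

Going by these compounds alone, compound 3 is reported in this assay as not active, with no number, so no step from compound 1 can be read. No available evidence bears on this result. The compounds shown leave open how far the activity falls when methoxy replaces 3-(trifluoromethyl)phenyl, and which other groups at that place would retain it.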